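Compound 3 to compound 4: a new group on the imine carbon

The source may report more compounds than this note shows. Statements on the series, on what has been measured and on what is new or still open speak of the compounds shown alone.

- compound 1 `O=C(N/N=C/c1ccc(F)cc1Cl)Nc1ccc(Oc2ccnc3[nH]ccc23)c(F)c1`: 1110 nM
- compound 2 `COc1ccc(/C=N/NC(=O)Nc2ccc(Oc3ccnc4[nH]ccc34)c(F)c2)cc1`: 1770 nM
- compound 3 `O=C(N/N=C/c1ccc(O)c(Br)c1)Nc1ccc(Oc2ccnc3[nH]ccc23)c(F)c1`: 1360 nM

In a functional assay on HepG2 cells (Homo sapiens) for antiproliferative activity, read by MTT assay, with a stated time of 72 h (on this read-out lower numbers stand for stronger inhibition and higher numbers for weaker inhibition), compound 3 gives 1360 nM, within the scatter of both other compounds, so no order can be read among the three. The measured steps all change the group at the same place as the next step: a 1.6-fold higher number from compound 1 to compound 2 (0.20 log units; within the scatter), a 1.2-fold higher number from compound 1 to compound 3 (0.09 log units; within the scatter) and a 1.3-fold lower number from compound 2 to compound 3 (0.11 log units; within the scatter). All three are small and lie within the scatter.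

Compound 4 `CN(C)CCn1cccc1/C=N/NC(=O)Nc1ccc(Oc2ccnc3[nH]ccc23)c(F)c1` has 1-(2-(dimethylamino)ethyl)-1H-pyrrol-2-yl in place of 3-bromo-4-hydroxyphenyl on a carbon with a double bond to nitrogen. For the measured compounds named here, none of the measured compounds has a five-membered aromatic ring or a dimethylamino group at this place. The three steps therefore bear on this change only indirectly: they show that this assay has so far responded little to exchanges here, but they do not cover a group of this kind.

No step beyond the scatter is expected, and no direction can be favoured. The expected change is a 1.1-fold higher number from compound 3 to compound 4 (0.04 log units; within the scatter). Compound 4 is estimated at 1500 nM, with an expected range of 450 nM to 5000 nM.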

Compound 4, half-maximal inhibitory concentration: 8980 nM
For compound 4 the middle estimate is 6.0-fold (0.78 log units) below the measured one; the whole stated range lies below it.
By their numbers in this assay, from the lowest: compounds 1, 3 and 2 (each within the scatter of the next); then compound 4.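

Working notes on the imine carbon: the place, a carbon with a double bond to nitrogen, is not indifferent to every exchange in this assay, since 1-(2-(dimethylamino)ethyl)-1H-pyrrol-2-yl in place of 3-bromo-4-hydroxyphenyl gives a 6.6-fold higher number from compound 3 to compound 4 (0.82 log units; beyond the scatter) in the series. The same group gives a 5.1-fold higher number from compound 2 to compound 4 (0.71 log units; beyond the scatter) against 4-methoxyphenyl and an 8.1-fold higher number from compound 1 to compound 4 (0.91 log units; beyond the scatter) against 2-chloro-4-fluorophenyl, so all three steps go towards weaker inhibition and lie beyond the scatter, whereas the exchanges among the three substituted phenyl groups stayed within it. Among the compounds shown, a group at this place can therefore cost activity, and no evidence on hand accounts for this result.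

Compound 4 differs from the others both in its five-membered aromatic ring and in its 2-(dimethylamino)ethyl chain, so the compounds shown do not tell which of the two goes with the higher number. As far as these compounds go, an unsubstituted 1H-pyrrol-2-yl group, a 1-methyl-1H-pyrrol-2-yl group or a phenyl group carrying the same dimethylamino chain would each separate these two parts, and whether a morpholine in place of the dimethylamino group behaves alike also remains open.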